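The source may hold more compounds than are shown below. What is called first, only, known or untested is meant among the compounds shown, and "the series" means these compounds.

Measured so far in a functional assay on HCT-116 cells (Homo sapiens) for cytotoxicity, read by MTT assay, with a stated time of 72 h; a lower number here means a stronger inhibitor, a higher number a weaker inhibitor: compound 1 `N[C@H]1CC[C@H](Nc2c(C(=O)NCc3ccc(F)cc3)nc(N3CCCCC3)c3cccnc23)CC1` gives 8000 nM. Compound 2 `NCCCNc1c(C(=O)NCc2ccc(F)cc2)ncc2cccnc12` reaches only the limit > 10000 nM. Compound 3 `NCCNc1c(C(=O)NCc2ccc(F)cc2)nc(Br)c2cccnc12` likewise reaches only the limit > 20000 nM.

Compound 3 thus stands at a limit (the limit of > 20000 nM in this assay, at which 1 of the 3 values shown sits); the one other limit (the limit of > 10000 nM in this assay, at which 1 of the 3 values shown sits) sits with compound 2, and only compound 1 gives a measured number. The next member, compound 4 `CNc1c(C(=O)NCc2ccc(F)cc2)nc(Br)c2cccnc12`, differs from compound 3 by hydrogen in place of aminomethyl on a saturated chain carbon bound to a nitrogen on an aromatic ring. Within the data shown here, no measured step of this kind exists among the three compounds, so no direction is set; the step in this assay is expected to be none beyond the scatter, most likely ending again at a limit. Compound 4 is expected at 30000 nM (range 10000 nM to 100000 nM), an estimated step that the limit leaves unreadable from compound 3 to compound 4.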

Compound 4, half-maximal inhibitory concentration: > 20000 nM
Compound 4 ended at the assay's limit; the forecaster's own chance of this, stated with the estimate: 75%; the middle value is on the limit's open side.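

Compound 3 and compound 4 both end at a limit, so no step can be read between them: the limit of > 20000 nM in this assay, at which 2 of the 4 values shown sit.

The compounds shown leave open whether 2-aminoethyl to methyl changes the read-out in this assay.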